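Replacing a Cyclic Amidine by a Sulfopropyl Chain

A few compounds are considered here, and "the series" means these few. Any claim that something is new, unique, unknown or untested is made for them only; others in the source may bear on it.

Measured compounds:
compound 1 `NC[C@@H]1CCCc2cc(S(=O)(=O)Cc3ccccc3)ccc21` 158 nM
compound 2 `NC[C@@H]1CCCc2cc(S(=O)(=O)c3cn[nH]c3)ccc21` 2 nM
compound 3 `O=C1CN=C(NC[C@@H]2CCCc3cc(S(=O)(=O)c4cccc(F)c4)ccc32)N1` 0.1 nM

In an assay on isolated protein for displacement of a labelled ligand from 5-hydroxytryptamine receptor 6 (Homo sapiens) (a lower number here means a stronger inhibitor, a higher number a weaker inhibitor), compound 3 gives the lowest number of the three; compound 2 is the nearest, and compound 1 the furthest. Compound 4 `O=S(=O)(O)CCCNC[C@@H]1CCCc2cc(S(=O)(=O)c3cccc(F)c3)ccc21` differs from compound 3 at the amine nitrogen: a group of 7 heavy atoms (3 carbon, 3 oxygen, 1 sulfur; no ring) in place of a group of 6 heavy atoms (3 carbon, 2 nitrogen, 1 oxygen; one five-membered non-aromatic ring with 2 hetero atoms), on an amine nitrogen. Among the compounds with values here, the only measured step, a 79-fold lower number from compound 1 to compound 2 (1.90 log units; beyond the scatter), concerns the group on the sulfonyl sulfur, not the amine, so no measured step bears directly on this change. Compounds 1 and 2, both with an unsubstituted amine, give higher numbers than compound 3, which alone carries a ring on that nitrogen. Compound 4 is therefore expected to show a 100-fold higher number from compound 3 to compound 4 (2.00 log units; beyond the scatter), and its estimated value in this assay is 10 nM (range 1 nM to 100 nM).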

Compound 4, inhibition constant: 1.26 nM
The estimate for compound 4 lay 7.9-fold (0.90 log units) above the measured number; low and high end bracket the measured number.
By their numbers in this assay, from the lowest: compound 3; then compounds 4 and 2 (each within the scatter of the next); then compound 1.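

On the amine nitrogen, 3-sulfopropyl in place of the ring-bearing group gives a 13-fold higher number from compound 3 to compound 4 (1.10 log units; beyond the scatter) in this assay, so the number depends on what this nitrogen carries. Even so, compound 4, whose group has no ring, gives 1.26 nM, so a ring on this nitrogen is not needed for a low number. Nothing available explains the step.

Going by these compounds, whether a carboxylic acid at the chain end, or a shorter or longer chain, would come closer to the ring-bearing group stays open. So does whether this step holds with 1H-pyrazol-4-yl or benzyl on the sulfonyl sulfur.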